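Swapping the aryl group on the sulfonyl of compound 2

The compounds below may be only part of what the source reports. "The series", "measured", "known", "first", "only" and "open" are said of these compounds alone.

Of the compounds shown here, two have been measured in an assay on isolated protein for displacement of a labelled ligand from metabotropic glutamate receptor 5 (Homo sapiens), with a stated time of 60 min, tested at 1 uM (on this read-out higher numbers stand for more inhibition at the one concentration tested (going by the name of the read-out) and lower numbers for less inhibition), so far. Compound 1 `COc1ccc(S(=O)(=O)c2cnc3c(F)cccc3c2N2CCC(C)CC2)cc1` gives 67% in this assay, and compound 2 `CC1CCN(c2c(S(=O)(=O)c3ccc(Cl)cc3)cnc3c(F)cccc23)CC1` gives 85%. For the measured compounds named here, the single one-place change between them, chloro in place of methoxy on an aromatic carbon, gave a number 18 percentage points higher from compound 1 to compound 2 (beyond the scatter), so compound 2 stands highest of the two numbers seen.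

Compound 3 `Cc1ccc(S(=O)(=O)c2cnc3c(F)cccc3c2N2CCC(C)CC2)cc1F` differs from compound 2 by 3-fluoro-4-methylphenyl in place of 4-chlorophenyl on a sulfonyl sulfur. Going by the values given here, no measured step touches this kind of change: the one step available swapped a group at the same position but to a different partner, so it only shows that a change at this position moved the number in this assay by a modest amount. A step of similar or smaller size is expected for compound 3, with no direction strongly indicated; the estimate for compound 3 in this assay is 75%, between 55% and 90%, which corresponds to an expected step of a number 10 percentage points lower from compound 2 to compound 3 (within the scatter).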

Compound 3, a percentage reported as inhibition, at one concentration (the size of the read-out at that concentration, not a potency): 93%
The estimate for compound 3 lay 18 percentage points below the measured number; the measured number lies above the stated range.
By their numbers in this assay, from the lowest: compound 1; then compounds 2 and 3 (each within the scatter of the next).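

In this assay, the aryl group on the sulfonyl sulfur can change from 4-chlorophenyl to 3-fluoro-4-methylphenyl with no reading beyond the usual scatter (a number 8 percentage points higher from compound 2 to compound 3 (within the scatter)). This shows that the position accepts more than one aryl group at this level of inhibition, and that a chlorine on the ring is not needed to hold it there. The change from 4-methoxyphenyl to 3-fluoro-4-methylphenyl gives a number 26 percentage points higher from compound 1 to compound 3 (beyond the scatter), so compounds 2 and 3 both read clearly higher than compound 1, but no measurement here explains why.

Going by these compounds, whether an amine or a carboxylic acid on this aryl group would keep the reading remains open. Also open, on these data alone, is whether compound 2 and compound 3 would separate in a full potency measurement.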